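The source may hold more compounds than are shown below. What is called first, only, known or untested is meant among the compounds shown, and "the series" means these compounds.

Measured so far in a functional assay on PC-3 cells (Homo sapiens) for inhibition, read by MTT assay, with a stated time of 72 h; on this read-out lower numbers stand for stronger inhibition and higher numbers for weaker inhibition:
- compound 1 `COc1cc2c(N[C@@H](C)c3ccccc3)ncnc2c(OC)c1OC`: 10000 nM
- compound 2 `COc1cc2c(Nc3ccc(Br)cc3Cl)ncnc2c(OC)c1OC`: 21000 nM

Compound 2 stands at the highest of the two numbers in this assay; the nearest is compound 1, and the step of a 2.1-fold higher number from compound 1 to compound 2 (0.32 log units; beyond the scatter) was modest though beyond the scatter. Compound 3 `COc1cc2c(Nc3ccc(O)cc3)ncnc2c(OC)c1OC` is the next member of the series. Its change from compound 2 is 4-hydroxyphenyl in place of 4-bromo-2-chlorophenyl on a nitrogen on an aromatic ring.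

For the measured compounds named here, only one measured step bears on this place, the exchange of the group on the nitrogen from compound 1 to compound 2, which moved the number a 2.1-fold higher number from compound 1 to compound 2 (0.32 log units; beyond the scatter). Going by the values given here, no measured pair shows a 4-hydroxyphenyl here, so the direction of the new change is not fixed by the data. Given that the one known exchange at this nitrogen was modest, the expected step from compound 2 to compound 3 is a 1.4-fold lower number from compound 2 to compound 3 (0.15 log units; within the scatter), a small move that may well stay within the scatter. The estimate for compound 3 in this assay is 15000 nM, with a range of 4000 nM to 50000 nM.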

Compound 3, half-maximal inhibitory concentration: 20100 nM
Beside the measured number, compound 3's estimate is 1.3-fold (0.13 log units) below it; the range from low to high includes it.
By their numbers in this assay, from the lowest: compounds 1, 3 and 2 (each within the scatter of the next, the first and the last beyond it).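

In this assay, the step of a 1.0-fold lower number from compound 2 to compound 3 (0.02 log units; within the scatter) shows that 4-hydroxyphenyl and 4-bromo-2-chlorophenyl on this nitrogen cannot be told apart, even though the exchange removes both halogens and brings in a hydrogen-bond donor and acceptor. The comparison with 1-phenylethyl, at a 2.0-fold higher number from compound 1 to compound 3 (0.30 log units; within the scatter), also stays within the scatter, so this exchange on the nitrogen separates compound 3 from neither neighbour, and the earlier step alone could not show this. Nothing available accounts for this lack of separation.

Still open, on these data alone, is whether a 4-aminophenyl or 4-carboxyphenyl group on this nitrogen would give a number beyond the scatter of these three compounds. Also open, as far as these compounds go, is whether replacing the methoxy groups of the shared core with longer ethoxy groups would move the number at all.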